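Boron-containing pyrrole aryl ketones: cytotoxicity on mouse fibroblasts

The compounds below may be only part of what the source reports. "The series", "measured", "known", "first", "only" and "open" are said of these compounds alone.

Measured compounds:
compound 1 `OB1OCc2ccc(-n3cccc3)cc21` — > 10 ug/mL in an ADME assay on L929 cells (Mus musculus) for cytotoxicity, read by resazurin assay, with a stated time of 72 h; on this read-out higher numbers stand for weaker inhibition and lower numbers for stronger inhibition
compound 2 `O=C(c1ccc(Cl)cc1)c1ccn(-c2ccc3c(c2)B(O)OC3)c1` — > 10 ug/mL in this assay

Compound 2 carries a ketone linking a chlorinated benzene ring to a pyrrole that bears the shared boron-containing bicyclic core. In this assay compound 2 gives only a limit, > 10 ug/mL, and not a number. Compound 1, which shares the same core with a plain pyrrole, is likewise reported only as a limit, > 10 ug/mL. Among the measured compounds shown here, both values therefore sit at the limit of > 10 ug/mL in this assay, at which 2 of the 2 values shown sit, so nothing can be said about an order between them, and no step between measured compounds can be counted.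

Compound 3 `O=C(c1ccc(O)cc1)c1ccn(-c2ccc3c(c2)B(O)OC3)c1` is the next compound to be measured. It differs from compound 2 in one place: hydroxy in place of chloro on an aromatic carbon. With both known values resting at the same limit, no step beyond the usual scatter in this assay is expected in either direction, and the most likely outcome is that compound 3 also returns a limit rather than a number. The half-maximal inhibitory concentration of compound 3 in this assay is estimated at 15 ug/mL, within the range 6 ug/mL to 40 ug/mL, which is the expected step that the limit leaves unreadable from compound 2 to compound 3.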

Compound 3, half-maximal inhibitory concentration: > 10 ug/mL
Compound 3 ended at the assay's limit; the forecaster's own chance of this, stated with the estimate: 75%; the middle value is on the limit's open side.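

In this assay compound 3 returned only a limit, as compound 2 did, so no step from compound 2 to compound 3 can be read: the limit of > 10 ug/mL in this assay, at which 3 of the 3 values shown sit.

The compounds shown leave open where the half-maximal inhibitory concentration of any of the three lies, and whether hydroxy in place of chloro shifts it at all.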